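The source may report more compounds than this note shows. Statements on the series, on what has been measured and on what is new or still open speak of the compounds shown alone.

Compound 1 `CCCCCCOP(=O)(O)OCCSC(=S)N1CCCCCC1` is the anchor of this short series: in an ADME assay on HEK293 cells (Homo sapiens) for inhibition, read by MTT assay, with stated times of 18 h and 4 h (a higher number here means a weaker inhibitor, a lower number a stronger inhibitor), compound 1 gives 70500 nM. Compound 2 `CCCCCCOP(=O)(O)OCCSC(=S)N1CCCCC1` carries piperidin-1-yl in place of azepan-1-yl on the thiocarbonyl carbon. In this assay compound 2 returns only a limit, > 100000 nM. Among the measured compounds shown here, the one measured step is an at least 1.4-fold higher number from compound 1 to compound 2 (0.15 log units; that floor lies within the scatter), so compound 2 stands at the weak end of what has been numbered, sitting at the limit of > 100000 nM in this assay, at which 1 of the 2 values shown sits.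

Compound 3 `CCCCCCOP(=O)(O)OCCSC(=S)N1CCN(C)CC1` is the next member, differing from compound 2 as follows: 4-methylpiperazin-1-yl in place of piperidin-1-yl on a thiocarbonyl carbon. For the measured compounds named here, the only step that bears on this change is the one from compound 1 to compound 2, which itself was small and open-ended, so no direction beyond the scatter can be read for the ring swap in this assay. The working expectation is therefore that compound 3 shows a number no higher from compound 2 to compound 3 (the limit leaves the size open), a step not distinguishable from the scatter. For compound 3 the estimated value in this assay is 100000 nM, with the expected range running from 40000 nM to 250000 nM.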

Compound 3, half-maximal inhibitory concentration: > 100000 nM
Compound 3 was reported as a limit; the forecaster's own chance of this, stated with the estimate: 60%; the middle value lies on the limit itself.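

In this assay compound 3 is reported only as a limit (> 100000 nM), so the six-membered ring with 2 hetero atoms, like the one with 1 hetero atom, gives no number at this position. Going from azepan-1-yl to 4-methylpiperazin-1-yl on the thiocarbonyl carbon gives an at least 1.4-fold higher number from compound 1 to compound 3 (0.15 log units; that floor lies within the scatter) and so adds no step beyond the scatter, while the step between the two limits cannot be read. Azepan-1-yl remains the only group here with a numbered value, and both six-membered rings now rest on the same limit: the limit of > 100000 nM in this assay, at which 2 of the 3 values shown sit.

Going by these compounds, how far compound 2 and compound 3 actually lie from compound 1 stays open, as does whether the added ring nitrogen and its methyl group change the reading at all. Also open, on these data alone, is whether a primary amine or a carboxylic acid in place of 4-methylpiperazin-1-yl on the thiocarbonyl carbon, or a longer chain in place of the hexyl chain on the shared core, would give a value that can be read in this assay.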